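One methyl added twice, on two different cores

This account rests on a few compounds, and the source may have more. Where it says the series, first, only, none or still open, it means among the compounds named here.

Measured so far:
compound 1, `CCn1c(C(F)(F)F)nc2cc(Cl)c(Cl)cc21`: 72900 nM
compound 2, `CC(C)n1c(C(F)(F)F)nc2cc(Cl)c(Cl)cc21`: 70500 nM
compound 3, `Cc1nc2cc(Cl)c(Cl)cc2n1C1CCCC1`: 40000 nM

In a functional assay on MCF7 cells (Homo sapiens) for cytotoxicity, read by MTT assay, with a stated time of 48 h (on this read-out higher numbers stand for weaker inhibition of growth and lower numbers for stronger inhibition of growth), compound 1 gives 72900 nM and compound 2 gives 70500 nM. The change between them is methyl in place of hydrogen on a saturated chain carbon bound to an aromatic nitrogen and a saturated chain carbon, and it made a 1.0-fold lower number from compound 1 to compound 2 (0.01 log units; within the scatter). In this assay compound 3 gives 40000 nM; the difference between its core and the core of compound 1 is not broken down here. Compound 4, `CCc1nc2cc(Cl)c(Cl)cc2n1C1CCCC1`, is not yet measured. It differs from compound 3 by methyl in place of hydrogen on a saturated chain carbon bound to an aromatic carbon. Among the measured compounds shown here, this is the same kind of change as the one between compound 1 and compound 2, but not the same: there the place was on a saturated chain carbon bound to an aromatic nitrogen and a saturated chain carbon, here it is on a saturated chain carbon bound to an aromatic carbon. The change occurs in two places among these compounds. Resting on a 1.0-fold lower number from compound 1 to compound 2 (0.01 log units; within the scatter), which lies within the scatter, the step expected for compound 4 is a 1.1-fold lower number from compound 3 to compound 4 (0.02 log units; within the scatter). Compound 4 is estimated at 38000 nM, with a range from 18000 nM to 80000 nM.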

Compound 4, concentration for 50% growth inhibition: 52000 nM
For compound 4 the middle estimate is 1.4-fold (0.14 log units) below the measured one; the range from low to high includes it.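

In this assay, the methyl in place of hydrogen gave a 1.3-fold higher number from compound 3 to compound 4 (0.11 log units; within the scatter), and set beside the earlier step, the change carried from one core to the other without a gap beyond the scatter: the same change on two cores in this assay, a 1.0-fold lower number (0.01 log units; within the scatter) from compound 1 to compound 2 and a 1.3-fold higher number (0.11 log units; within the scatter) from compound 3 to compound 4, 1.3-fold (0.13 log units) apart, within the scatter of two such steps. On these two cores, then, both steps are small enough to lie within the scatter, although the change sits at a different place on each. This does not show that the change would stay as small on other cores or at other places, since a single pair on each core cannot establish a rule for the series.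

The compounds shown leave open what a chain longer than ethyl would give at this place in this assay. They also leave open what an amine or a carboxylic acid on that chain would give.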